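Ethoxy for bromo on the anilide of the nitrophenyl core

This account rests on a few compounds, and the source may have more. Where it says the series, first, only, none or still open, it means among the compounds named here.

Of the compounds shown here, two have been measured in a functional assay on HCT-116 cells (Homo sapiens) for cytotoxicity, read by MTT assay, with a stated time of 48 h; a higher number here means a weaker inhibitor, a lower number a stronger inhibitor. Compound 1 `CCOc1ccc(NC(=O)c2cn(-c3ccccc3)nc2-c2ccc(C)cc2)cc1` gives 780 nM in this assay. Compound 2 `O=C(Nc1ccc(Br)cc1)c1cn(-c2ccccc2)nc1-c1ccc([N+](=O)[O-])cc1` gives 4080 nM in this assay, the higher of the two numbers; its nearest neighbour is compound 1, whose number is lower by a gap beyond the scatter. Among the measured compounds shown here, the two compounds differ at two places at once, so no single step between measured compounds can be read from them.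

Compound 3 `CCOc1ccc(NC(=O)c2cn(-c3ccccc3)nc2-c2ccc([N+](=O)[O-])cc2)cc1` is not yet measured. It differs from compound 2 by ethoxy in place of bromo on an aromatic carbon. The anilide of compound 3 is that of compound 1, the other aryl group that of compound 2. For the measured compounds named here, with no step between measured compounds to guide it, the change from compound 2 to compound 3 is expected to lower the number in this assay by a modest margin, a 1.9-fold lower number from compound 2 to compound 3 (0.27 log units; within the scatter), possibly no further than the scatter. Compound 3 is estimated at 2200 nM in this assay, within a range from 600 nM to 7000 nM.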

Compound 3, half-maximal inhibitory concentration: 390 nM
Compound 3: the middle estimate sits 5.6-fold (0.75 log units) above what was measured; measured number below the stated range.
By their numbers in this assay, from the lowest: compounds 3 and 1 (each within the scatter of the next); then compound 2.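

In this assay, among the compounds shown here, ethoxy in place of bromo on an aromatic carbon gives a 10-fold lower number from compound 2 to compound 3 (1.02 log units; beyond the scatter), the first step at this position that can be read with the rest of the molecule held constant, and a large one. With the 4-ethoxyphenyl amide held constant, nitro in place of methyl on the other aryl group gives a 2.0-fold lower number from compound 1 to compound 3 (0.30 log units; within the scatter), so this change does not separate the two compounds in this assay. No measurement shown here bears on what lies behind the large ethoxy step.

Going by these compounds, whether the ethoxy-for-bromo step carries over to the methyl-bearing aryl group of compound 1 remains open. Also open, on these data alone, is how a propoxy chain, a hydroxyl or an amine would read in place of ethoxy on this ring.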